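Replacing a Methoxy with an Oxan-4-yl Ring

The source may report more compounds than this note shows. Statements on the series, on what has been measured and on what is new or still open speak of the compounds shown alone.

Measured so far in an assay on CHO cells for inhibition of sodium- and chloride-dependent glycine transporter 1 (Homo sapiens), read by scintillation counting; a higher number here means that more compound is needed for the effect, a lower number that less compound is needed:
- compound 1, `C[C@H](Oc1ccc(S(C)(=O)=O)cc1C(=O)N1Cc2ccc(C(F)(F)F)cc2C1)C(F)(F)F`: 21 nM
- compound 2, `COc1ccc2c(c1)CN(C(=O)c1cc(S(C)(=O)=O)ccc1O[C@@H](C)C(F)(F)F)C2`: 180 nM
- compound 3, `COc1cccc2c1CN(C(=O)c1cc(S(C)(=O)=O)ccc1O[C@@H](C)C(F)(F)F)C2`: 1940 nM

Compound 2 gives the second highest of these three numbers in this assay. Compound 1 sits closer to it, and compound 3, which carries its methoxy at a different position of the shared core, is furthest away. Among the compounds with values here, only one measured step touches the position changed here: an 8.6-fold higher number from compound 1 to compound 2 (0.93 log units; beyond the scatter). This shows that the substituent at this place of the core can shift the result well beyond the scatter.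

The new compound 4, `C[C@H](Oc1ccc(S(C)(=O)=O)cc1C(=O)N1Cc2ccc(C3CCOCC3)cc2C1)C(F)(F)F`, differs from compound 2 in this way: oxan-4-yl in place of methoxy on an aromatic carbon. The oxan-4-yl enters at the very position where methoxy and trifluoromethyl were compared. Within the data shown here, since the trifluoromethyl of compound 1 gave a lower number than the methoxy of compound 2, a substituent other than methoxy at this place seems able to move the number down, but no measured step tells how a saturated ring behaves there. A modest change is therefore expected, most likely toward a lower number: a 1.8-fold lower number from compound 2 to compound 4 (0.26 log units; within the scatter). The estimate for compound 4 in this assay is 100 nM, within a range from 30 nM to 400 nM.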

Compound 4, half-maximal effective concentration: 14 nM
For compound 4 the middle estimate is 7.1-fold (0.85 log units) above the measured one, outside the stated range (below it).
By their numbers in this assay, from the lowest: compounds 4 and 1 (each within the scatter of the next); then compound 2; then compound 3.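

In this assay, within the data shown here, putting oxan-4-yl in place of methoxy gives a 13-fold lower number from compound 2 to compound 4 (1.11 log units; beyond the scatter) and so shows that this position takes a six-membered non-aromatic ring, something no earlier compound could show. Set against the trifluoromethyl group, the same ring gives a 1.5-fold lower number from compound 1 to compound 4 (0.18 log units; within the scatter) and that step stays within the scatter, so these two groups cannot be told apart at this place, and of the three groups compared here only methoxy stands out, with the higher number. Nothing shown gives a reason for these numbers.

The compounds shown leave open whether the ring oxygen of oxan-4-yl matters, which an all-carbon cyclohexyl ring at this place could test, and how an amine such as piperidin-4-yl would behave. A longer open chain, such as butyl, also remains untested here in the compounds shown.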